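A few compounds are considered here, and "the series" means these few. Any claim that something is new, unique, unknown or untested is made for them only; others in the source may bear on it.

In a functional assay on A549 cells (Homo sapiens) for antiproliferative activity, read by MTT assay, with a stated time of 48 h (a lower number here means a stronger inhibitor of growth, a higher number a weaker inhibitor of growth), compound 3 (`CCN(Cc1ccc(C(=O)NO)cc1)c1ncc(-c2ccc(C)cc2)s1`) gives 2700 nM, within the scatter of compound 2 (`Cc1ccc(-c2cnc(N(Cc3ccccc3)Cc3ccc(C(=O)NO)cc3)s2)cc1`) at 4410 nM and clearly lower than compound 1 (`CCCCCN(Cc1ccc(C(=O)NO)cc1)c1ncc(-c2ccc(C)cc2)s1`) at 9140 nM. The change to compound 4 (`Cc1ccc(OCCCCN(Cc2ccc(C(=O)NO)cc2)c2ncc(-c3ccc(C)cc3)s2)cc1`) is 2-(4-methylphenoxy)ethyl in place of hydrogen on a saturated chain carbon, two bonds along the chain from a nitrogen on an aromatic ring. Among the compounds with values here, the closest precedent is at that same carbon: a 3.4-fold lower number from compound 1 to compound 3 (0.53 log units; beyond the scatter), so read in reverse, adding propyl there raised the number modestly. Against that, a 1.6-fold lower number from compound 2 to compound 3 (0.21 log units; within the scatter), so a phenyl on the carbon bound to the nitrogen shows no clear penalty. A modest rise is therefore expected, with the step estimated as a 2.2-fold higher number from compound 3 to compound 4 (0.35 log units; beyond the scatter). For compound 4 the estimated value is 6000 nM, with an expected range of 2200 nM to 14000 nM.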

Compound 4, concentration for 50% growth inhibition: 8630 nM
Compound 4: middle estimate off by 1.4-fold (0.16 log units), on the low side; measured number inside the range.
By their numbers in this assay, from the lowest: compounds 3, 2, 4 and 1 (each within the scatter of the next, the first and the last beyond it).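

At this carbon in this assay, 2-(4-methylphenoxy)ethyl in place of hydrogen gives a 3.2-fold higher number from compound 3 to compound 4 (0.50 log units; beyond the scatter), so a group carrying an aromatic ring at the chain end is tolerated no better than the plain chain of compound 1. With 4-methylphenoxy in place of methyl there is a 1.1-fold lower number from compound 1 to compound 4 (0.02 log units; within the scatter), which is within the scatter, and a 2.0-fold higher number from compound 2 to compound 4 (0.29 log units; within the scatter) is also within it. Nothing given here accounts for these steps. Going by these compounds, whether an amine or a carboxylic acid at the chain end would read differently from 4-methylphenoxy remains open. Also open, on these data alone, is how a propyl or butyl chain on that nitrogen would read.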